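The compounds below may be only part of what the source reports. "The series", "measured", "known", "first", "only" and "open" are said of these compounds alone.

In a functional assay on SW-620 cells (Homo sapiens) for inhibition, read by MTT assay, with a stated time of 72 h (on this read-out lower numbers stand for stronger inhibition and higher numbers for weaker inhibition), compound 1 (`COc1cc(NC(C)CCCNC(=O)NNC(=O)Nc2ccc(C(F)(F)F)cc2)c2ncccc2c1`) gives 12000 nM and so holds the lowest of the three numbers measured. Compound 2 (`COc1cc(NC(C)CCCNC(=O)Nc2ccc(F)cc2)c2ncccc2c1`) gives 25000 nM and compound 3 (`COc1cc(NC(C)CCCNC(=O)Nc2cccc(O)c2)c2ncccc2c1`) gives 27000 nM on the same read-out, and both numbers are higher than that of compound 1 by more than the usual scatter.

Compound 4 (`COc1cc(NC(C)CCCNC(=O)NNC(=O)Nc2cccc(C(F)(F)F)c2)c2ncccc2c1`) differs from compound 1 in one place (3-(trifluoromethyl)phenyl in place of 4-(trifluoromethyl)phenyl on an amide-type nitrogen) where 3-(trifluoromethyl)phenyl stands in place of 4-(trifluoromethyl)phenyl on an amide-type nitrogen. The two compounds have the same atoms, joined differently.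

Going by the values given here, the one measured step that bears on this change is a 1.1-fold higher number from compound 2 to compound 3 (0.03 log units; within the scatter) and it also exchanges one substituted phenyl group for another on an amide-type nitrogen. Among the compounds with values here, this is indirect evidence, since compound 2 and compound 3 differ from compound 1 in more than the phenyl group, and no measured pair moves the trifluoromethyl group itself.

On that basis, the expected step is a 1.1-fold higher number from compound 1 to compound 4 (0.03 log units; within the scatter) and no change beyond the scatter is expected in this assay here. For compound 4 the estimate is 13000 nM with an expected range from 6000 nM to 27000 nM on this read-out.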

Compound 4, half-maximal inhibitory concentration: 21000 nM
Estimate against measurement, compound 4: 1.6-fold (0.21 log units) below; the measured number falls inside the stated range.
By their numbers in this assay, from the lowest: compounds 1, 4, 2 and 3 (each within the scatter of the next, the first and the last beyond it).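

Going by these compounds alone, this result is the first direct reading of the trifluoromethyl group's placement on the phenyl ring, which the earlier compounds, all lacking such a pair, could not give. In this assay, 3-(trifluoromethyl)phenyl in place of 4-(trifluoromethyl)phenyl on the amide-type nitrogen gives a 1.8-fold higher number from compound 1 to compound 4 (0.24 log units; within the scatter) and so the two placements cannot be told apart on this read-out, even though the step is larger than the one between the 4-fluorophenyl and 3-hydroxyphenyl compounds. No measurement shown here offers an account of this step.

The compounds shown leave open how a phenyl ring carrying a chlorine, a nitrile or a methoxy group in place of trifluoromethyl would read in this assay when attached through the same linker as in compound 1. They also leave open whether an unsubstituted phenyl group, or a pyridine ring in place of the phenyl ring, would keep the number of compound 1 within the scatter, or move it beyond the scatter in either direction.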